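Phenylsulfonyl on an amine nitrogen: the step to compound 3

The compounds below may be only part of what the source reports. "The series", "measured", "known", "first", "only" and "open" are said of these compounds alone.

In a functional assay on PC-3 cells (Homo sapiens) for inhibition, read by CellTiter-Glo, with a stated time of 72 h (a lower number here means that less compound is tolerated, a higher number that more compound is tolerated), the measured compounds read as follows
Compound 1 (`CC1=C(CC(=O)N(C)CCN(C)C)c2cc(F)ccc2/C1=C\c1nc2ccccc2s1`): 5880 nM
Compound 2 (`CC1=C(CC(=O)N(C)CCN(C)C(=O)[C@@H](N)C(C)C)c2cc(F)ccc2/C1=C\c1ccc([S+](C)[O-])cc1`): > 50000 nM (a limit)

Compound 2 stands at the limit of > 50000 nM in this assay, at which 1 of the 2 values shown sits, and this is a limit of the assay, not a number. Compound 3 (`CC1=C(CC(=O)N(C)CCN(C)S(=O)(=O)c2ccccc2)c2cc(F)ccc2/C1=C\c1ccc([S+](C)[O-])cc1`) carries phenylsulfonyl in place of (1-amino-2-methylpropyl)carbonyl on an amine nitrogen. Among the measured compounds shown here, no measured pair shows this change. In this assay a moderate step towards lower values is expected, with an at least 1.6-fold lower number from compound 2 to compound 3 (0.22 log units; that floor lies within the scatter) as the estimate. Compound 3 is estimated at 30000 nM (expected range 9000 nM to 70000 nM).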

Compound 3, half-maximal cytotoxic concentration: 8200 nM
Compound 3: the middle estimate sits 3.7-fold (0.56 log units) above what was measured; measured number below the stated range.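

In this assay, among the compounds shown here, phenylsulfonyl in place of (1-amino-2-methylpropyl)carbonyl on an amine nitrogen gives an at least 6.0-fold lower number from compound 2 to compound 3 (0.78 log units; beyond the scatter), the first sign that the group at this nitrogen can move the number. The true size of the step remains unknown, because compound 2 gives only a limit: the limit of > 50000 nM in this assay, at which 1 of the 3 values shown sits.

For the compounds shown here, this single change brings in an aromatic ring and a sulfonyl and removes the amino group and the stereocentre together, and the one pair cannot separate these parts. Open, from the compounds shown here alone, is how a benzoyl or a methylsulfonyl group on the same nitrogen would read.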